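From a bulky urea substituent to a bare amide hydrogen

The compounds below may be only part of what the source reports. "The series", "measured", "known", "first", "only" and "open" are said of these compounds alone.

Among the measured compounds shown here, compound 2, `CC(C)(C)NC(=O)N1CC1C#N`, is the only member of this small set with a real number: in a functional assay on MCF7 cells (Homo sapiens) for inhibition (a higher number here means a weaker inhibitor, a lower number a stronger inhibitor), compound 2 gives 120000 nM. Compound 1, `CCCCNC(=O)N1CC1C#N`, carries a butyl chain where compound 2 carries a tert-butyl group. Compound 1 in this assay gives > 12000 nM, which is a limit of the assay rather than a number. The step that the limit leaves unreadable from compound 1 to compound 2 therefore cannot be read in size or direction, because the limit of > 12000 nM in this assay, at which 1 of the 2 values shown sits, hides one of its two ends. Compound 3, `N#CC1CN1C(N)=O`, is the next change: hydrogen in place of tert-butyl on an amide-type nitrogen. For the measured compounds named here, no readable measured step bears on this change, since the single measured step in the set is the unreadable one. With nothing to lean on, compound 3 is expected to show a step of a 1.2-fold lower number from compound 2 to compound 3 (0.08 log units; within the scatter) of no size beyond the scatter, in no particular direction, and this is an estimate rather than a finding. Compound 3 is thus expected to give 100000 nM in this assay, with a wide range from 15000 nM to 600000 nM, and a fair chance that only a limit is returned.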

Compound 3, half-maximal inhibitory concentration: > 54000 nM
Compound 3 gave a limit, no number; the forecaster's own chance of this, stated with the estimate: 40%; the middle value is on the limit's open side.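

The steps linking compound 3 to compound 1 and to compound 2 cannot be read in size or direction, because compound 3 returned only a limit, not a number: the limit of > 54000 nM in this assay, at which 1 of the 3 values shown sits.

Still open, as far as these compounds go, is whether hydrogen in place of tert-butyl or butyl on the amide-type nitrogen changes inhibition at all in this assay.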